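Swapping sulfanyl for a selenium group on a fused core

A few compounds are considered here, and "the series" means these few. Any claim that something is new, unique, unknown or untested is made for them only; others in the source may bear on it.

Compound 1 `C[Se]c1nc([Se]C)c2cccnc2n1`, a functional assay on HT-29 cells (Homo sapiens) for cytotoxicity, read by MTT assay, with a stated time of 72 h; a higher number here means that more compound is tolerated, a lower number that less compound is tolerated: "not determined" (no result reported)
Compound 2 `Sc1nc(NCc2ccccc2)c2ccccc2n1`, in this assay: > 100000 nM
Compound 3 `Nc1nc([SeH])nc2ncccc12`, in this assay: > 100000 nM

Compound 2 stands only at a limit of the assay, not at a measured number. The value of compound 3 is likewise a limit. Compound 1 has no number at all. Among the values shown there is the limit of > 100000 nM in this assay, at which 2 of the 3 values shown sit, so nothing shows a difference between any two of these compounds, and no step between measured compounds is available.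

Compound 4 `C[Se]c1nc(NCc2ccccc2)c2ccccc2n1` differs from compound 2 by a group of 2 heavy atoms (1 carbon, 1 selenium; no ring) in place of one sulfur atom, on an aromatic carbon; in words, a group of 2 heavy atoms (1 carbon, 1 selenium; no ring) in place of one sulfur atom, on an aromatic carbon. Within the data shown here, with no measured step to draw on, the expectation is that the change from compound 2 to compound 4 brings no shift beyond the usual scatter of this assay. For compound 4 the estimated value is 150000 nM, expected to lie between 40000 nM and 500000 nM. This estimate means a step that the limit leaves unreadable from compound 2 to compound 4 is expected, and most likely the assay again reports only a limit.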

Compound 4, concentration lethal to 50% of the cells: > 100000 nM
Compound 4: no number, only a limit; the forecaster's own chance of this, stated with the estimate: 70%; the middle value lies beyond the limit too.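

Among these compounds, compound 2 and compound 4 both stop at a limit of the assay rather than a measured number, so no step between them can be read: the limit of > 100000 nM in this assay, at which 3 of the 4 values shown sit.

The compounds shown leave open whether replacing sulfanyl with the group holding carbon and selenium changes the result in this assay at all.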